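The source may hold more compounds than are shown below. What is called first, only, known or untested is meant among the compounds shown, and "the series" means these compounds.

The measured compounds, all tested in an ADME assay on HUVEC cells (Homo sapiens) for antiproliferative activity, read by MTT assay, with a stated time of 48 h; a higher number here means a weaker inhibitor, a lower number a stronger inhibitor:

Compound 1, `N#CC1=C(N)Oc2c(c3nc4ccccc4nc3c3ccccc23)C12C(=O)N(Cc1cnnn1-c1cccc(Cl)c1)c1ccccc12` — in this assay compound 1 gives only the limit > 50000 nM.
Compound 2, `COc1ccc(-n2nncc2CN2C(=O)C3(C(C#N)=C(N)Oc4c3c3nc5ccccc5nc3c3ccccc43)c3ccccc32)cc1` — in this assay compound 2 gives only the limit > 50000 nM.
Compound 3, `N#CC1=C(N)Oc2c(c3nc4ccccc4nc3c3ccccc23)C12C(=O)N(Cc1cnnn1-c1cccc(S(N)(=O)=O)c1)c1ccccc12` — in this assay compound 3 gives 38600 nM.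

Going by the values given here, compound 3 thus holds the only true number of the three; the other two sit at a limit of the assay (the limit of > 50000 nM in this assay, at which 2 of the 3 values shown sit). The steps to it are small: from compound 1 the change was an at least 1.2-fold lower number from compound 1 to compound 3 (0.11 log units; that floor lies within the scatter), and from compound 2 it was an at least 1.2-fold lower number from compound 2 to compound 3 (0.11 log units; that floor lies within the scatter). Between compound 1 and compound 2 the step is a step that the two limits leave unreadable from compound 1 to compound 2.

The next compound, compound 4, is `Cc1ccc(-n2nncc2CN2C(=O)C3(C(C#N)=C(N)Oc4c3c3nc5ccccc5nc3c3ccccc43)c3ccccc32)c(C)c1`. It differs from compound 3 by 2,4-dimethylphenyl in place of 3-sulfamoylphenyl on an aromatic nitrogen. Among the compounds with values here, the one measured step on this same aromatic nitrogen, from compound 2 to compound 3, was an at least 1.2-fold lower number from compound 2 to compound 3 (0.11 log units; that floor lies within the scatter), and it is the only aryl swap there with a readable floor. Because two of the three values are limits (the limit of > 50000 nM in this assay, at which 2 of the 3 values shown sit), there is little room to read a trend; the expectation is a step of no size beyond the scatter, if anything toward a weaker result.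

Compound 4 is therefore estimated to give 55000 nM, with an expected range from 25000 nM to 120000 nM. This estimate corresponds to an expected 1.4-fold higher number from compound 3 to compound 4 (0.15 log units; within the scatter).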

Compound 4, half-maximal inhibitory concentration: > 50000 nM
Compound 4: only a limit was reported (the forecaster's own chance of this, stated with the estimate: 60%); the middle value lies beyond the limit too.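

Going by these compounds alone, compound 4 gives only a limit in this assay, so a group made of carbon alone, 2,4-dimethylphenyl, now joins 3-chlorophenyl and 4-methoxyphenyl at the same limit on this aromatic nitrogen: the limit of > 50000 nM in this assay, at which 3 of the 4 values shown sit. Measured against compound 3, the only compound with a true number, the change shows an at least 1.2-fold higher number from compound 3 to compound 4 (0.11 log units; that floor lies within the scatter), so the new compound adds no sign that 3-sulfamoylphenyl stands apart from the other aryl groups. The steps to compound 4 from compound 1 and from compound 2 cannot be read, as both ends of each are limits.

The compounds shown leave open how far apart these four compounds truly lie, and whether any group on this aromatic nitrogen can give a step clearly beyond the scatter. A phenyl ring bearing an amine or a carboxylic acid, or a longer alkyl chain in place of the aryl ring, could show whether this position can move the result at all.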